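Removing one chloro from the anilino ring of the dithioester series

The source may report more compounds than this note shows. Statements on the series, on what has been measured and on what is new or still open speak of the compounds shown alone.

Measured compounds:
Compound 1, `CCCCCCCCCCCSC(=S)C1=C(Nc2ccc(Cl)cc2Cl)CC(C)(C)CC1=O`: in a functional assay on cells (blood, Homo sapiens) for inhibition, read by chemiluminescence, with a stated time of 30 min (on this read-out higher numbers stand for weaker inhibition and lower numbers for stronger inhibition), compound 1 gives > 100 ug/mL, a limit of the assay and not a number.
Compound 2, `CC1(C)CC(=O)C(C(=S)SCCO)=C(Nc2ccc(Cl)cc2Cl)C1`: in this assay compound 2 gives > 100 ug/mL, likewise a limit.

Compound 1 therefore stands only at a limit, with no number of its own. For the measured compounds named here, the single measured step, a step that the two limits leave unreadable from compound 1 to compound 2, is left unreadable by the two limits, and it alters the chain rather than the anilino ring. Compound 3, `CCCCCCCCCCCSC(=S)C1=C(Nc2ccc(Cl)cc2)CC(C)(C)CC1=O`, differs from compound 1 by hydrogen in place of chloro on an aromatic carbon. Going by the values given here, no measured step bears on this change. Because of the limit of > 100 ug/mL in this assay, at which 2 of the 2 values shown sit, compound 3 is expected to stay near the limit, with the expected step that the limit leaves unreadable from compound 1 to compound 3. Compound 3 is estimated at 150 ug/mL, ranging from 50 ug/mL to 500 ug/mL.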

Compound 3, half-maximal inhibitory concentration: > 100 ug/mL
Compound 3 gave a limit, no number; the forecaster's own chance of this, stated with the estimate: 75%; the middle value lies beyond the limit too.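

No step from compound 1 to compound 3 can be read, since both give only a limit and no number: the limit of > 100 ug/mL in this assay, at which 3 of the 3 values shown sit.

The compounds shown leave open what removing the chloro or changing the chain does to inhibition.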